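A larger group on the carbonyl of compound 1

A few compounds are considered here, and "the series" means these few. Any claim that something is new, unique, unknown or untested is made for them only; others in the source may bear on it.

compound 1 `COc1ccccc1OCC1SCCN1C(C)=O` gives 46 mg/kg
compound 2 `CCOC(=O)CC(=O)N1CCSC1COc1ccccc1O` gives 20 mg/kg
compound 3 `CCOC(=O)CC(=O)N1CC[S+]([O-])C1COc1ccccc1OC` gives 27 mg/kg

In a functional assay on the whole organism for inhibition, with Cavia porcellus as the target (a higher number here means that more compound is needed for the effect, a lower number that less compound is needed), compound 1 (46 mg/kg) and compound 2 (20 mg/kg) are separated by a gap beyond the scatter, with compound 1 needing the larger dose, but compound 1 lies within the scatter of compound 3 (27 mg/kg). Compound 4 (`CCOC(=O)C(C)(C)C(=O)N1CCSC1COc1ccccc1OC`) keeps the core of compound 1 and carries 1-(ethoxycarbonyl)-1-methylethyl in place of methyl on a carbonyl carbon. Among the compounds with values here, no measured pair isolates this change. Compound 2 (20 mg/kg) and compound 3 (27 mg/kg) also carry an ethoxycarbonyl group, though both differ from compound 4 elsewhere, so only a modest lowering, not clearly beyond the scatter, seems likely. A step of a 1.8-fold lower number from compound 1 to compound 4 (0.26 log units; within the scatter) is therefore expected. The estimated dose for compound 4 is 25 mg/kg with an expected range of 10 mg/kg to 60 mg/kg in this test.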

Compound 4, dose for half-maximal effect: 61 mg/kg
Compound 4: middle estimate off by 2.4-fold (0.39 log units), on the low side; the measured number lies above the stated range.
By their numbers in this assay, from the lowest: compounds 2, 3, 1 and 4 (each within the scatter of the next, the first and the last beyond it).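

In this assay, within the data shown here, putting 1-(ethoxycarbonyl)-1-methylethyl in place of methyl on a carbonyl carbon gives a 1.3-fold higher number from compound 1 to compound 4 (0.12 log units; within the scatter) as the first comparison in which only this place differs. This position therefore accepts a group of 8 heavy atoms, against 1 for methyl, with no shift beyond the scatter. No measurement shown offers an explanation for this result. Only this one replacement is available at this place. Going by these compounds, whether a carboxylic acid, an amine or a longer chain on the carbonyl carbon would move the dose beyond the scatter remains open.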